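A propargyl ester change carried onto a second aryl core

A few compounds are considered here, and "the series" means these few. Any claim that something is new, unique, unknown or untested is made for them only; others in the source may bear on it.

The series rests on a shared core that carries an ester at two positions and an aryl substituent. Compound 1 `C#CCOC(=O)CC1C(C(=O)OCC)=C(N)Oc2ccc(-c3cccc(N)c3)cc21` gives 3400 nM in a functional assay on HL-60 cells (Homo sapiens) for cytotoxicity, read by CellTiter-Blue, with a stated time of 48 h; on this read-out higher numbers stand for weaker inhibition and lower numbers for stronger inhibition. Compound 2 `C#CCOC(=O)CC1C(C(=O)OCC#C)=C(N)Oc2ccc(-c3cccc(N)c3)cc21` differs from it by ethynyl in place of methyl on a saturated chain carbon bound to an oxygen next to a carbonyl group and gives 1240 nM in this assay, a step of a 2.7-fold lower number from compound 1 to compound 2 (0.44 log units; beyond the scatter). Compound 3 `C#CCOC(=O)CC1C(C(=O)OCC)=C(N)Oc2ccc(-c3ccc(NCC)cc3)cc21` differs from compound 1 by 4-(ethylamino)phenyl in place of 3-aminophenyl on an aromatic carbon; in this assay compound 3 gives 33000 nM, a step of a 9.7-fold higher number from compound 1 to compound 3 (0.99 log units; beyond the scatter), and it stands highest of the three numbers.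

Compound 4 `C#CCOC(=O)CC1C(C(=O)OCC#C)=C(N)Oc2ccc(-c3ccc(NCC)cc3)cc21` has not been measured. It differs from compound 3 by ethynyl in place of methyl on a saturated chain carbon bound to an oxygen next to a carbonyl group, the same change that separates compound 1 from compound 2, set on the core of compound 3 rather than that of compound 1. Among the measured compounds shown here, only one earlier example of this change exists, so the expectation rests on it alone. Compound 4 is expected to show a step of a 2.8-fold lower number from compound 3 to compound 4 (0.44 log units; beyond the scatter) from compound 3 in this assay, because the earlier step of a 2.7-fold lower number from compound 1 to compound 2 (0.44 log units; beyond the scatter) pointed the same way. Compound 4 is thus estimated at 12000 nM, with a range of 5000 nM to 30000 nM.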

Compound 4, half-maximal inhibitory concentration: 7270 nM
Compound 4: middle estimate off by 1.7-fold (0.22 log units), on the high side; low and high end bracket the measured number.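

In this assay, ethynyl in place of methyl on the ester chain gives a 4.5-fold lower number from compound 3 to compound 4 (0.66 log units; beyond the scatter), so the change points the same way on the core of compound 3 as on the core of compound 1, and the two steps cannot be told apart: the same change on two cores in this assay, a 2.7-fold lower number (0.44 log units; beyond the scatter) from compound 1 to compound 2 and a 4.5-fold lower number (0.66 log units; beyond the scatter) from compound 3 to compound 4, 1.7-fold (0.22 log units) apart, within the scatter of two such steps. Read along the other edge, 4-(ethylamino)phenyl in place of 3-aminophenyl gives a 5.9-fold higher number from compound 2 to compound 4 (0.77 log units; beyond the scatter), and this step likewise agrees with its earlier counterpart: the same change on two cores in this assay, a 9.7-fold higher number (0.99 log units; beyond the scatter) from compound 1 to compound 3 and a 5.9-fold higher number (0.77 log units; beyond the scatter) from compound 2 to compound 4, 1.7-fold (0.22 log units) apart, within the scatter of two such steps. Across these four compounds the two changes therefore add up without visible interference, but this rests on a single pair of cores in one cell line and does not show that the ester change would carry over to other aryl groups or other assays.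

The compounds shown leave open whether 4-aminophenyl or 3-(ethylamino)phenyl would separate the effect of the ethyl group on the amine from that of the amine's place on the ring. Also open, going by these compounds, is how the propargyl step would read beside a carboxylic acid or a longer chain at the same ester.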